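The compounds below may be only part of what the source reports. "The series", "measured", "known", "first", "only" and "open" are said of these compounds alone.

Measured so far in a functional assay on CHO-K1 cells for antagonist activity at C-X-C chemokine receptor type 3 (Homo sapiens), read by FLIPR and calcium flux; on this read-out lower numbers stand for stronger inhibition and higher numbers for weaker inhibition:
compound 1, `CC1(C)[C@@H]2CC[C@@]1(CS(=O)(=O)N1CCN(c3ccc(C(F)(F)F)cn3)C(c3ccccc3)C1)C(=O)C2`
compound 2, `CC1(C)[C@@H]2CC[C@@]1(CS(=O)(=O)N1CCN(c3ncc(C(F)(F)F)cc3[N+](=O)[O-])CC1)C(=O)C2`.

In this assay compound 1 has only a limit, > 31600 nM, not a number; this is the limit noted as the limit of > 31600 nM in this assay, at which 1 of the 2 values shown sits. For the measured compounds named here, compound 2 gives 3160 nM in this assay, and this is the only actual number so far, so compound 2 stands alone as the single measured point against which anything new must be judged.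

Compound 3, `CC1(C)[C@@H]2CC[C@@]1(CS(=O)(=O)N1CCN(c3ncc(C(F)(F)F)cc3Cl)CC1)C(=O)C2`, has not been measured. It differs from compound 2 in one place: chloro in place of nitro on an aromatic carbon of a six-membered aromatic ring with one nitrogen, two atoms from the ring nitrogen and meta to a trifluoromethyl group. Going by the values given here, no step between measured compounds exists to calibrate this change, so the expectation rests on compound 2 alone. The step from compound 2 to compound 3 is expected to be a 1.6-fold higher number from compound 2 to compound 3 (0.20 log units; within the scatter), a modest loss that may well fall within the scatter. Compound 3 is therefore estimated at 5000 nM in this assay, with a range from 1500 nM to 20000 nM.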

Compound 3, half-maximal inhibitory concentration: 398 nM
Compound 3: middle estimate off by 13-fold (1.10 log units), on the high side; the measured number lies below the stated range.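

In this assay, for the compounds shown here, the aromatic carbon two atoms from the ring nitrogen and meta to a trifluoromethyl group is sensitive to its substituent: chloro in place of nitro gives a 7.9-fold lower number from compound 2 to compound 3 (0.90 log units; beyond the scatter), the first calibrated change at this position. Nitro, with its hydrogen-bond acceptors, is therefore not required here for a measurable number, and a single chlorine atom serves better on this read-out. Nothing measured in the series points to a cause for this step.

The compounds shown leave open whether a fluoro, a methoxy, an amine or a nitrile at this position would give a lower or a higher number than chloro. Also open, going by these compounds, is how far either group stands from plain hydrogen at this position on the same core.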